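Methyl removal on the acyl ring: compound 2 to compound 3

The source may hold more compounds than are shown below. What is called first, only, known or untested is meant among the compounds shown, and "the series" means these compounds.

Compound 2 `COc1ccc(C2=NN(C(=O)c3ccc(C)nc3Cl)C(c3ccc(OCc4ccccc4)cc3)C2)cc1` gives 10500 nM in a functional assay on WM 266-4 cells (Homo sapiens) for antiproliferative activity, read by MTT assay, with a stated time of 24 h (a higher number here means a weaker inhibitor of growth, a lower number a stronger inhibitor of growth), the higher of the two numbers recorded so far, while compound 1 `COc1ccc(C2=NN(C(=O)c3cccnc3Cl)C(c3ccc(Cl)cc3)C2)cc1` gives 780 nM. Among the measured compounds shown here, no single-point step between measured compounds exists, so that gap is only what the two values show. Compound 3 `COc1ccc(C2=NN(C(=O)c3cccnc3Cl)C(c3ccc(OCc4ccccc4)cc3)C2)cc1` differs from compound 2 in one place: hydrogen in place of methyl on an aromatic carbon. For the measured compounds named here, with no measured step to lean on, the change is expected to be small, toward a lower number and perhaps within the scatter, as a 1.8-fold lower number from compound 2 to compound 3 (0.24 log units; within the scatter). Compound 3 is expected to give 6000 nM in this assay, between 2500 nM and 15000 nM.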

Compound 3, concentration for 50% growth inhibition: 9150 nM
The estimate for compound 3 lay 1.5-fold (0.18 log units) below the measured number; the range from low to high includes it.
By their numbers in this assay, from the lowest: compound 1; then compounds 3 and 2 (each within the scatter of the next).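

Hydrogen in place of methyl on the aromatic carbon next to the ring nitrogen gives a 1.1-fold lower number from compound 2 to compound 3 (0.06 log units; within the scatter) in this assay with the benzyloxy group held constant, so this position shows no clear response to that change. Benzyloxy in place of chloro gives a 12-fold higher number from compound 1 to compound 3 (1.07 log units; beyond the scatter) and is the only one of the two single-place steps beyond the scatter. No measurement on hand explains either step.

Open, on these data alone, are an amine or a methoxy group on that same carbon, and whether the methyl change reads the same with chloro in place of benzyloxy.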